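This account rests on a few compounds, and the source may have more. Where it says the series, first, only, none or still open, it means among the compounds named here.

Compound 1 `O=C(Nc1cccc(-n2cc(-c3ccncc3)c(-c3ccc(Cl)c(O)c3)n2)c1)Nc1cccc(C(F)(F)F)c1` carries the shared core with a 4-chloro-3-hydroxyphenyl group and a 3-(trifluoromethyl)phenyl urea. In a functional assay on ACHN cells (Homo sapiens) for inhibition, read by sulforhodamine B assay, with a stated time of 48 h (on this read-out lower numbers stand for higher toxicity in this test and higher numbers for lower toxicity in this test), compound 1 gives only a limit of > 32500 nM. Compound 2 `COc1cc(-c2nn(-c3cccc(NC(=O)c4cccc(C(F)(F)F)c4)c3)cc2-c2ccncc2)ccc1Cl` bears the methoxy analogue of that aryl group and an amide instead of the urea; in this assay compound 2 likewise reaches only a limit of > 50000 nM. Compound 3 `COc1cc(-c2nn(-c3cccc(NC(=O)Nc4ccc(Cl)c(Cl)c4)c3)cc2-c2ccncc2)ccc1Cl` keeps the methoxy group and returns to a urea, now with a (3,4-dichlorophenyl)amino in place of the 3-(trifluoromethyl)phenyl on the carbonyl carbon; in this assay compound 3 again shows only a limit of > 50000 nM. The step that the two limits leave unreadable from compound 2 to compound 3 therefore cannot be read. Compound 3 thus stands at one of the limits that all three values share, as the limit of > 32500 nM in this assay, at which 1 of the 3 values shown sits, and the limit of > 50000 nM in this assay, at which 2 of the 3 values shown sit, show. Compound 4 `O=C(Nc1cccc(-n2cc(-c3ccncc3)c(-c3ccc(Cl)c(O)c3)n2)c1)Nc1ccc(Cl)c(Cl)c1` differs from compound 3 by hydrogen in place of methyl on an oxygen on an aromatic ring. Compound 1 carries the same hydroxy group against the urea of the first kind and is a limit as well. Within the data shown here, no measured step gives a readable size, so no shift beyond the scatter is expected from compound 3 to compound 4, a step that the limit leaves unreadable from compound 3 to compound 4. Compound 4 is expected to give about 60000 nM in this assay, within 20000 nM to 200000 nM, most probably again only as a limit.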

Compound 4, concentration lethal to 50% of the cells: > 32500 nM
Compound 4: no number, only a limit; the forecaster's own chance of this, stated with the estimate: 85%; the middle value lies beyond the limit too.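

Compound 4, like compound 1 and compound 3, gives only a limit in this assay, so neither its step from compound 3 nor its step from compound 1 can be read. The compounds shown leave open whether either change alters toxicity in this test at all.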